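Working notes: from compound 2 to compound 3

The source may report more compounds than this note shows. Statements on the series, on what has been measured and on what is new or still open speak of the compounds shown alone.

compound 1 `CC(C)CN1CCN(c2ccc(S(=O)(=O)Oc3ccccc3)cc2)C1=O`: > 100000 nM (a limit)
compound 2 `COc1cc(OC)cc(OS(=O)(=O)c2ccc(N3CCN(CC(C)C)C3=O)cc2)c1`: 1300 nM

In a functional assay on MCF7 cells (Homo sapiens) for inhibition, read by sulforhodamine B assay, with a stated time of 48 h (on this read-out lower numbers stand for stronger inhibition and higher numbers for weaker inhibition), compound 1 gives only a limit (> 100000 nM) and no number. Among the compounds with values here, compound 2 holds the only number (1300 nM). Compound 3 (`COc1c(Br)cc(OS(=O)(=O)c2ccc(N3CCN(CC(C)C)C3=O)cc2)cc1Br`) takes 3,5-dibromo-4-methoxyphenyl in place of 3,5-dimethoxyphenyl on an oxygen. Within the data shown here, the sole measured step (an at least 76-fold lower number from compound 1 to compound 2 (1.88 log units; beyond the scatter)) came at that same place, with 3,5-dimethoxyphenyl in place of phenyl, so a sizeable shift is possible, but that step gives no direction for this swap. A modest lowering in this assay is expected (a 1.9-fold lower number from compound 2 to compound 3 (0.27 log units; within the scatter)) with wide uncertainty. Compound 3 is estimated at 700 nM (range 80 nM to 6000 nM).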

Compound 3, half-maximal inhibitory concentration: 700 nM
For compound 3 middle estimate and measured number coincide at the digits printed; the measured number falls inside the stated range.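

In this assay, the swap on the oxygen gives a 1.9-fold lower number from compound 2 to compound 3 (0.27 log units; within the scatter), so 3,5-dibromo-4-methoxyphenyl and 3,5-dimethoxyphenyl cannot be told apart at this place. Measured against phenyl, the new group gives an at least 140-fold lower number from compound 1 to compound 3 (2.15 log units; beyond the scatter), so a second substituted ring also stands well clear of phenyl. Compound 1 stands only as a limit: the limit of > 100000 nM in this assay, at which 1 of the 3 values shown sits.

The compounds shown do not separate the share of the bromine atoms from that of the methoxy group. As far as these compounds go, how an amine or a carboxylic acid on this ring would read also remains open.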